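The compounds below may be only part of what the source reports. "The series", "measured", "known", "first", "only" and "open" are said of these compounds alone.

compound 1 `CN(C)C(=O)c1cc2cnc(Nc3ccc(NC(=O)C4(C(=O)Nc5ccc(Cl)cc5)CC4)cc3)nc2n1C1CCCC1`: 85.3%
compound 2 `CN(C)C(=O)c1cc2cnc(Nc3ccc(NC(=O)C4(C(=O)Nc5ccccc5F)CC4)cc3)nc2n1C1CCCC1`: 82.6%
compound 3 `CN(C)C(=O)c1cc2cnc(Nc3ccc(NC(=O)C4(C(=O)Nc5ccc(O)cc5)CC4)cc3)nc2n1C1CCCC1`: 90.9%

All three values come from a functional assay on OVCAR-5 cells (Homo sapiens) for inhibition, read by CCK-8 assay, with a stated time of 72 h, tested at 10 uM; on this read-out higher numbers stand for more inhibition of growth at the one concentration tested and lower numbers for less inhibition of growth. Compound 2 cannot be separated from the other two. The numbers show a number 2.7 percentage points lower from compound 1 to compound 2 (within the scatter), and also a number 8.3 percentage points higher from compound 2 to compound 3 (within the scatter).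

The next compound is compound 4 `CN(C)C(=O)c1cc2cnc(Nc3ccc(NC(=O)C4(C(=O)Nc5ccccc5)CC4)cc3)nc2n1C1CCCC1`. The change is hydrogen in place of fluoro on an aromatic carbon. In words, this is hydrogen in place of fluoro on an aromatic carbon, so that 2-fluorophenyl becomes phenyl.

Among the measured compounds shown here, no measured pair isolates this exact change, and no measured compound carries the phenyl group itself. The nearest evidence is the three steps that alter the same aryl group on the amide-type nitrogen. These are a number 2.7 percentage points lower from compound 1 to compound 2 (within the scatter), a number 8.3 percentage points higher from compound 2 to compound 3 (within the scatter) and a number 5.6 percentage points higher from compound 1 to compound 3 (within the scatter). Across 4-chlorophenyl, 2-fluorophenyl and 4-hydroxyphenyl, none of these steps leaves the scatter, and no compound in this small set goes against that.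

No step beyond the scatter is therefore expected, and no direction can be argued from these data. The expected step is a number 1.4 percentage points higher from compound 2 to compound 4 (within the scatter). For compound 4 the estimated value is 84%, with an expected range from 74% to 92%.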

Compound 4, percent growth inhibition at one concentration: 77.1%
Estimate against measurement, compound 4: 6.9 percentage points above; low and high end bracket the measured number.
By their numbers in this assay, from the lowest: compounds 4, 2, 1 and 3 (each within the scatter of the next, the first and the last beyond it).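

In this assay, among the compounds shown here, the phenyl group of compound 4 gives the only step in this aryl series that leaves the scatter, with a number 13.8 percentage points lower from compound 3 to compound 4 (beyond the scatter) as the reading, so the aryl group on the amide-type nitrogen can now be seen to influence this read-out, though only modestly. The two remaining comparisons with phenyl do not separate their groups: the record shows a number 5.5 percentage points lower from compound 2 to compound 4 (within the scatter) for 2-fluorophenyl and a number 8.2 percentage points lower from compound 1 to compound 4 (within the scatter) for 4-chlorophenyl, so neither fluoro nor chloro can be told from hydrogen, and the resolved difference is limited to 4-hydroxyphenyl against phenyl. Nothing available on these compounds accounts for that difference.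

From the compounds shown here alone, whether an amine or a carboxylic acid in place of hydroxy on the 4-substituted phenyl group would stand with compound 3 or with compound 4 remains open. Also open, going by these compounds, is whether the gap between compound 3 and compound 4 would persist over a range of concentrations, as each value here rests on a single tested concentration.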